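Methylation of the phenol oxygen in the pyridyl-pyrazole series

This account rests on a few compounds, and the source may have more. Where it says the series, first, only, none or still open, it means among the compounds named here.

Compound 1 `O=C(Nc1cccc(-n2cc(-c3ccncc3)c(-c3ccc(Cl)c(O)c3)n2)c1)Nc1ccc(Cl)c(Cl)c1` is measured in a functional assay on TK-10 cells (Homo sapiens) for inhibition, read by sulforhodamine B assay, with a stated time of 48 h (on this read-out higher numbers stand for weaker inhibition of growth and lower numbers for stronger inhibition of growth), at 1910 nM. Compound 2 `COc1cc(-c2nn(-c3cccc(NC(=O)Nc4cccc(C(F)(F)F)c4)c3)cc2-c2ccncc2)ccc1Cl` gives 1310 nM and compound 3 `COc1cc(-c2nn(-c3cccc(NC(=O)Nc4ccc(Cl)c(C(F)(F)F)c4)c3)cc2-c2ccncc2)ccc1Cl` gives 1520 nM. Compound 1 sits at the upper end of the three numbers, but its gaps to compound 3 and to compound 2 both lie inside the scatter of this assay, so the three cannot be ordered. Among the measured compounds shown here, the only measured single-point step, a 1.2-fold higher number from compound 2 to compound 3 (0.06 log units; within the scatter), is also within the scatter.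

Compound 4 `COc1cc(-c2nn(-c3cccc(NC(=O)Nc4ccc(Cl)c(Cl)c4)c3)cc2-c2ccncc2)ccc1Cl` differs from compound 1 by methyl in place of hydrogen on an oxygen on an aromatic ring, the change from 4-chloro-3-hydroxyphenyl to 4-chloro-3-methoxyphenyl. For the measured compounds named here, no measured pair isolates this change; compound 2 and compound 3 already carry the methoxy, and their values sit in the same band as compound 1. The step is therefore expected to stay within the scatter, with no direction that can be read from the data. Compound 4 is expected at 1500 nM, with a range of 700 nM to 3200 nM. The expected step is a 1.3-fold lower number from compound 1 to compound 4 (0.10 log units; within the scatter).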

Compound 4, concentration for 50% growth inhibition: 1430 nM
Beside the measured number, compound 4's estimate is 1.0-fold (0.02 log units) above it; measured number inside the range.
By their numbers in this assay, from the lowest: compounds 2, 4, 3 and 1 (each within the scatter of the next).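

In this assay, among the compounds shown here, the step of a 1.3-fold lower number from compound 1 to compound 4 (0.13 log units; within the scatter) is the first direct reading of this position: methyl in place of hydrogen on an oxygen on an aromatic ring, that is hydroxy to methoxy, gives no change that can be told from the scatter. With the 4-chloro-3-methoxyphenyl group held fixed, the aryl group on the amide-type nitrogen also gives no readable change: the step of a 1.1-fold lower number from compound 3 to compound 4 (0.03 log units; within the scatter) is chloro in place of trifluoromethyl, and the step of a 1.1-fold higher number from compound 2 to compound 4 (0.04 log units; within the scatter) is 3,4-dichlorophenyl in place of 3-(trifluoromethyl)phenyl. No supporting data bear on these results.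

As far as these compounds go, what an amine or a longer chain such as ethoxy would do in place of the methoxy remains open. From the compounds shown here alone, a single pair carries the hydroxy to methoxy change, so whether it behaves the same way with the 3-(trifluoromethyl)phenyl group also remains open.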